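Fluoro for Methoxy on a Carbamate Selenocyanate

This account rests on a few compounds, and the source may have more. Where it says the series, first, only, none or still open, it means among the compounds named here.

Compound 1 `COc1ccc(OC(=O)Nc2ccc([Se]C#N)cc2)cc1`: 25200 nM
Compound 2 `CCOC(=O)Nc1ccc([Se][Se]c2ccc(NC(=O)OCC)cc2)cc1`: 16100 nM

Of the compounds shown here, two have been measured so far in an ADME assay on BEAS-2B cells (Homo sapiens) for cytotoxicity, read by MTT assay, with a stated time of 72 h; a lower number here means a stronger inhibitor of growth, a higher number a weaker inhibitor of growth. Compound 1 gives 25200 nM, the higher of the two numbers. Compound 2 gives 16100 nM, and the gap between the two lies within the usual scatter of the assay, so the two compounds show no real difference in growth inhibition.

Compound 3 `N#C[Se]c1ccc(NC(=O)Oc2ccc(F)cc2)cc1` is the next compound to be tested. Going by the values given here, it is built on the core of compound 1, and the single change is fluoro in place of methoxy on an aromatic carbon. Among the compounds with values here, no measured pair shows what such a swap does here, so the step cannot be read from the data. Small exchanges of this kind on an aromatic ring are expected to move this assay little, and nothing beyond the scatter is expected in either direction. The estimated step of a 1.1-fold lower number from compound 1 to compound 3 (0.06 log units; within the scatter) is therefore small. Compound 3 is expected to give about 22000 nM, within a range from 9000 nM to 55000 nM.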

Compound 3, concentration for 50% growth inhibition: 19800 nM
For compound 3 the middle estimate is 1.1-fold (0.05 log units) above the measured one; the measured number falls inside the stated range.
By their numbers in this assay, from the lowest: compounds 2, 3 and 1 (each within the scatter of the next).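

Going by these compounds alone, the first measured swap at this position, fluoro in place of methoxy on an aromatic carbon para to a large group, gives a 1.3-fold lower number from compound 1 to compound 3 (0.10 log units; within the scatter) in this assay. On this single pair, replacing methoxy with one fluorine atom, and so removing its carbon and oxygen, leaves growth inhibition unchanged beyond the usual scatter, so this position tolerates the exchange in this assay. Nothing available here gives a reason for this result.

A single pair cannot show whether a very different group at the same position, such as an amine, a carboxylic acid or a longer alkoxy chain, would move the number beyond the scatter. It also leaves open whether fluoro in place of methoxy would behave the same way on another core.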